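The compounds below may be only part of what the source reports. "The series", "measured", "known", "first", "only" and "open" are said of these compounds alone.

Compound 1 `CN1Cc2c(N)cccc2C(c2ccc(Cl)cc2)C1`: 1.6 mg/kg
Compound 2 `Cc1ccc(C2CN(C)Cc3c(N)cccc32)cc1`: 1.6 mg/kg
Compound 3 `CCNCC(=O)Nc1cccc2c1CN(C)CC2c1ccc(Cl)cc1`: 24 mg/kg

All three were tested in a functional assay on the whole organism for inhibition, with Mus musculus as the target; on this read-out lower numbers stand for an effect already at smaller amounts and higher numbers for an effect only at larger amounts of compound. Compound 1 and compound 2 differ in one place, (methyl in place of chloro on an aromatic carbon), and that step gave no change at the digits printed from compound 1 to compound 2 (within the scatter). Compound 3 carries a different core from compound 1; the difference between the two cores is ((ethylamino)methyl)carbonyl in place of hydrogen on a nitrogen on an aromatic ring, and that step gave a 15-fold higher number from compound 1 to compound 3 (1.18 log units; beyond the scatter), leaving compound 3 with the highest number of the three. Compound 4 `CCNCC(=O)Nc1cccc2c1CN(C)CC2c1ccc(C)cc1` has not yet been measured. It stands to compound 3 as compound 2 stands to compound 1: the change is methyl in place of chloro on an aromatic carbon, the same change as in the measured pair, here made on the core of compound 3. Because no change at the digits printed from compound 1 to compound 2 (within the scatter) left the number unchanged, the step is expected to be no change at the digits printed from compound 3 to compound 4 (within the scatter). Compound 4 is therefore estimated at 24 mg/kg, expected to lie between 10 mg/kg and 60 mg/kg.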

Compound 4, dose for half-maximal effect: about 45 mg/kg
Compound 4: the middle estimate sits 1.9-fold (0.27 log units) below what was measured; measured number inside the range.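

In this assay, methyl in place of chloro on the second core gave a 1.9-fold higher number from compound 3 to compound 4 (0.27 log units; within the scatter), and this agrees with the same change on the first core: the same change on two cores in this assay, no change at the digits printed (within the scatter) from compound 1 to compound 2 and a 1.9-fold higher number (0.27 log units; within the scatter) from compound 3 to compound 4, 1.9-fold (0.27 log units) apart, within the scatter of two such steps. Adding the ((ethylamino)methyl)carbonyl group to the methyl-bearing core gave a 28-fold higher number from compound 2 to compound 4 (1.45 log units; beyond the scatter), and this agrees with the same addition to the chloro-bearing core: the same change on two cores in this assay, a 15-fold higher number (1.18 log units; beyond the scatter) from compound 1 to compound 3 and a 28-fold higher number (1.45 log units; beyond the scatter) from compound 2 to compound 4, 1.9-fold (0.27 log units) apart, within the scatter of two such steps. Each change therefore carried over between these two pairs, but this does not establish a rule for other cores or other groups, nor does it explain the size of either step.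

The compounds shown leave open how a fluoro or methoxy group on the same aromatic carbon would behave. They also leave open what a longer chain or a carboxylic acid would do in place of the ethylamino end.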